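Swapping Bromo for Hydroxy on a Shared Core

The source may hold more compounds than are shown below. What is called first, only, known or untested is meant among the compounds shown, and "the series" means these compounds.

Of the compounds shown here, three built on one shared core have been tested in an assay for inhibition of Dihydrofolate reductase (Bos taurus); a higher number here means a weaker inhibitor, a lower number a stronger inhibitor. Compound 1 `O=[N+]([O-])c1ccccc1/C=N/c1nc2ccccc2s1` gives 53.1 nM, compound 2 `Clc1ccc(/C=N/c2nc3ccccc3s2)cc1` gives 41.5 nM, and compound 3 `Brc1ccc(/C=N/c2nc3ccccc3s2)cc1` gives 45.5 nM. Going by the values given here, the one step measured in one place, a 1.1-fold higher number from compound 2 to compound 3 (0.04 log units; within the scatter), describes bromo in place of chloro on an aromatic carbon. Compound 3 sits among its two neighbours rather than apart from them: compound 2 is nearest and compound 1 furthest, and both gaps fall within the scatter, so the three numbers cannot be told apart.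

Compound 4 `Oc1ccc(/C=N/c2nc3ccccc3s2)cc1` arises from compound 3 through (hydroxy in place of bromo on an aromatic carbon). Among the compounds with values here, no measured step covers a halogen giving way to a hydroxy group; the only step at hand, a 1.1-fold higher number from compound 2 to compound 3 (0.04 log units; within the scatter), exchanges one halogen for another and barely moves this assay. Since the three measured compounds stay together whatever sits on that carbon, no movement beyond the scatter is expected in either direction, though the range must stay wide. Compound 4 is therefore estimated at 50 nM, with a range from 20 nM to 130 nM. This estimate means a step of a 1.1-fold higher number from compound 3 to compound 4 (0.04 log units; within the scatter), expected to remain within the scatter.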

Compound 4, half-maximal inhibitory concentration: 51.2 nM
Beside the measured number, compound 4's estimate is 1.0-fold (0.01 log units) below it, within the range that was stated.
By their numbers in this assay, from the lowest: compounds 2, 3, 4 and 1 (each within the scatter of the next).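

Going by these compounds alone, until compound 4, this carbon had carried only halogens, so the earlier compounds could not show whether a group of a different kind would shift the number. In this assay, hydroxy in place of bromo gives a 1.1-fold higher number from compound 3 to compound 4 (0.05 log units; within the scatter), and hydroxy in place of chloro gives a 1.2-fold higher number from compound 2 to compound 4 (0.09 log units; within the scatter), so a group bringing the hydrogen-bond donor and acceptor that both halogens lack still cannot be told apart from them. No supporting information is available to explain this result.

Still open, as far as these compounds go, is whether the number would stay put with quite different groups on this carbon, such as an amine, a carboxylic acid or a longer chain. From the compounds shown here alone, it is also open whether hydroxy would read the same on another carbon of this six-membered aromatic ring.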